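The compounds below may be only part of what the source reports. "The series", "measured", "known", "first", "only" and "open" are said of these compounds alone.

Measured in a functional assay on SK-OV-3 cells (Homo sapiens) for antiproliferative activity, read by MTT assay, with a stated time of 48 h; a lower number here means a stronger inhibitor, a higher number a weaker inhibitor:

- compound 1 `CCNC(=O)Nc1nc(-c2ccc(OCC)cc2)c(-c2cc(OC)c(OC)c(OC)c2)s1`: 29.2 nM
- compound 2 `CCOc1ccc(-c2nc(N(Cc3ccccc3)Cc3ccccc3)sc2-c2cc(OC)c(OC)c(OC)c2)cc1`: > 5000 nM (a limit, not a number)
- compound 3 `CCOc1ccc(-c2nc(NS(=O)(=O)c3ccccc3C(F)(F)F)sc2-c2cc(OC)c(OC)c(OC)c2)cc1`: > 5000 nM (a limit, not a number)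

Only compound 1 gives a number in this assay. Compound 3 reads > 5000 nM, which is a limit of the assay. Compound 3 and compound 2 both stand at the limit of > 5000 nM in this assay, at which 2 of the 3 values shown sit.

The next compound, compound 4 `CCOc1ccc(-c2nc(NS(=O)(=O)c3ccc([N+](=O)[O-])cc3OC)sc2-c2cc(OC)c(OC)c(OC)c2)cc1`, differs from compound 3 in one place. It carries 2-methoxy-4-nitrophenyl in place of 2-(trifluoromethyl)phenyl on a sulfonyl sulfur. For the measured compounds named here, no measured pair shows what such an exchange does in this assay, so the expectation rests on compound 3 alone. Compound 3 has the same sulfonamide nitrogen and sulfonyl sulfur and reads > 5000 nM, a limit, so no step beyond the scatter is expected in either direction. The expected step is a number no higher from compound 3 to compound 4 (the limit leaves the size open). The assay may well report only a limit again. Compound 4 is estimated at 5000 nM, with an expected range from 1000 nM to 20000 nM.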

Compound 4, half-maximal inhibitory concentration: > 5000 nM
Compound 4 ended at the assay's limit; the forecaster's own chance of this, stated with the estimate: 70%; the middle value lies on the limit itself.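

In this assay compound 3 and compound 4 each give only a limit, not a number, so no step can be read between them, and the exchange of 2-(trifluoromethyl)phenyl for 2-methoxy-4-nitrophenyl has no readable size. The compounds shown leave open whether in this assay any group on the sulfonyl sulfur gives a number rather than a limit.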